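Extending the piperazine of compound 2 with a sulfamoyl group

This account rests on a few compounds, and the source may have more. Where it says the series, first, only, none or still open, it means among the compounds named here.

Of the compounds shown here, two built on one shared core have been measured in an ADME assay on MT4 cells (Homo sapiens) for cytotoxicity, read by MTT assay, with a stated time of 5 days; on this read-out lower numbers stand for higher toxicity in this test and higher numbers for lower toxicity in this test. Compound 1 `Cc1cc(/C=C/C#N)cc(C)c1Oc1nc(Nc2ccc(CN3CCNCC3)cc2)nc2ccsc12` gives 3970 nM. Compound 2 `Cc1cc(/C=C/C#N)cc(C)c1Oc1nc(Nc2ccc(N3CCNCC3)cc2)nc2ccsc12` gives 5730 nM. Within the data shown here, the only measured step, a 1.4-fold higher number from compound 1 to compound 2 (0.16 log units; within the scatter), leaves the two numbers inside the scatter of each other, so on these data compound 2 cannot be told apart from compound 1, its nearest and only neighbour.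

Compound 3 `Cc1cc(/C=C/C#N)cc(C)c1Oc1nc(Nc2ccc(CN3CCN(S(N)(=O)=O)CC3)cc2)nc2ccsc12` has not yet been measured in this assay. It differs from compound 2 by (4-sulfamoylpiperazin-1-yl)methyl in place of piperazin-1-yl on an aromatic carbon: a (4-sulfamoylpiperazin-1-yl)methyl group enters where the piperazin-1-yl stood, para to a large group. Among the measured compounds shown here, no measured step covers the addition of the sulfamoyl group, and the one step that exists, the swap between piperazin-1-yl and (piperazin-1-yl)methyl, stayed within the scatter. Nothing in the data therefore points to a move beyond the scatter. The step from compound 2 to compound 3 is estimated as a 1.0-fold lower number from compound 2 to compound 3 (0.02 log units; within the scatter). Compound 3 is accordingly expected at 5500 nM, within a range from 2500 nM to 12000 nM.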

Compound 3, half-maximal cytotoxic concentration: 145000 nM
Estimate against measurement, compound 3: 26-fold (1.42 log units) below; the whole stated range lies below it.
By their numbers in this assay, from the lowest: compounds 1 and 2 (each within the scatter of the next); then compound 3.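

In this assay, among these compounds, a sulfamoyl group in place of hydrogen on the ring amine nitrogen gives a 37-fold higher number from compound 1 to compound 3 (1.56 log units; beyond the scatter), the first change in this short series to move the number beyond the scatter, and here the higher number stands for lower toxicity in this test. The step that also swaps the attachment of the ring to the aromatic carbon, a 25-fold higher number from compound 2 to compound 3 (1.40 log units; beyond the scatter), is large as well, whereas the swap between (piperazin-1-yl)methyl and piperazin-1-yl alone, a 1.4-fold higher number from compound 1 to compound 2 (0.16 log units; within the scatter), stayed within the scatter, so among these three compounds the large steps appear only where the sulfamoyl group is present. No measurement given here accounts for this rise in the number.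

The compounds shown leave open whether the large step belongs to the sulfamoyl group itself or would also follow from another group on that ring nitrogen, such as an acetyl, a methylsulfonyl or a carboxamide. They also leave open whether a sulfamoyl group on the piperazin-1-yl of compound 2, with no methylene in the link to the aromatic carbon, would give a step of similar size.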